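Swapping trifluoromethyl for fluoro in a cytotoxicity assay

The source may report more compounds than this note shows. Statements on the series, on what has been measured and on what is new or still open speak of the compounds shown alone.

Compounds measured so far in a functional assay on CEM-SS cells (Homo sapiens) for cytotoxicity; a higher number here means a weaker inhibitor, a lower number a stronger inhibitor
compound 1 `Nc1nc2cc(Cl)c(Cl)cc2n1Cc1ccc(F)cc1` – 30000 nM
compound 2 `FC(F)(F)c1ccc(Cn2c(Cl)nc3cc(Cl)c(Cl)cc32)cc1` – > 100000 nM (a limit of the assay, not a number)

Compound 2 has no exact value on this scale, only the limit > 100000 nM. That limit is also the ceiling of the assay, as the limit of > 100000 nM in this assay, at which 1 of the 2 values shown sits, shows. For the measured compounds named here, compound 1 supplies the only true number so far, at 30000 nM.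

The next compound, compound 3 `Fc1ccc(Cn2c(Cl)nc3cc(Cl)c(Cl)cc32)cc1`, is reached from compound 2 by a single change, (fluoro in place of trifluoromethyl on an aromatic carbon). The fluoro group sits para to a large group, on a six-membered aromatic ring of carbon only. Going by the values given here, no measured step between compounds gives a direct guide to the size of this change in this assay.

A modest move towards a stronger inhibitor is expected, and the reading may well stay at the limit. The expected step is an at least 1.6-fold lower number from compound 2 to compound 3 (0.22 log units; that floor lies within the scatter). For compound 3 the estimated value is 60000 nM, with an expected range from 20000 nM to 100000 nM.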

Compound 3, half-maximal inhibitory concentration: > 100000 nM
Compound 3: no number, only a limit; the forecaster's own chance of this, stated with the estimate: 45%; middle value at least 1.6-fold (0.22 log units) from the limit.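

In this assay compound 3 gives > 100000 nM, which is a limit of the assay and not a number. The exchange of trifluoromethyl for fluoro at this place, para to a large group, cannot be read, because compound 2 and compound 3 both stand at a limit: the limit of > 100000 nM in this assay, at which 2 of the 3 values shown sit.

For the compounds shown here, the one readable step is an at least 3.3-fold higher number from compound 1 to compound 3 (0.52 log units; beyond the scatter), and it belongs to a different change, chloro in place of amino on an aromatic carbon, with the fluoro group the same in both compounds.

As far as these compounds go, whether trifluoromethyl and fluoro differ at all at this place stays open, and a compound carrying trifluoromethyl together with the amino group of compound 1 could test this away from the limit. From the compounds shown here alone, how a methoxy group or a nitrile would read at the same place, or a methylamino group in place of chloro, is also open.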